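A Chloro Swap on a Modest Growth Inhibitor

A few compounds are considered here, and "the series" means these few. Any claim that something is new, unique, unknown or untested is made for them only; others in the source may bear on it.

Going by the values given here, in a functional assay on NCI-H23 cells (Homo sapiens) for inhibition, read by sulforhodamine B assay, with a stated time of 48 h, tested at 10 uM (a higher number here means more inhibition of growth at the concentration tested, a lower number less inhibition of growth), compound 1 `COc1ccc(-c2nc3sc(-c4ccccc4)cn3n2)cc1` gives 28% and stands highest of the two numbers so far. Compound 2 `COc1cc(-c2nc(N)n(CC(=O)Nc3ccc(/C(C)=N\O)cc3)n2)cc(OC)c1OC` gives 4.21% and sits lower by a gap beyond the scatter. Compound 3 `COc1ccc(-c2nc3sc(-c4ccc(Cl)cc4)cn3n2)cc1` differs from compound 1 in one place (chloro in place of hydrogen on an aromatic carbon): chloro in place of hydrogen on an aromatic carbon, so phenyl becomes 4-chlorophenyl. Among the compounds with values here, no measured pair shows this change, so the expected step of a number 5 percentage points higher from compound 1 to compound 3 (within the scatter) is small, upward, and may well stay within the scatter. Compound 3 is expected to give 33% (estimated range 15% to 55%).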

Compound 3, percent growth inhibition at one concentration: 41.5%
Compound 3: the middle estimate sits 8.5 percentage points below what was measured; low and high end bracket the measured number.
By their numbers in this assay, from the lowest: compound 2; then compound 1; then compound 3.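

Going by these compounds alone, this is the first pair of measured compounds that differ in one place, and it shows that this position on the outer phenyl ring can change the read-out. In this assay, the change from phenyl to 4-chlorophenyl gives a number 13.5 percentage points higher from compound 1 to compound 3 (beyond the scatter), a modest step from a single atom added to the ring. Within the data shown here, nothing measured so far explains why the number rises.

This single pair cannot show whether the step is specific to chloro. Going by these compounds, a fluoro, a methoxy or an amine at the same carbon remains open, as does chloro on another carbon of that ring.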